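Replacing the 3,4-dinitrophenyl group of compound 1

The source may report more compounds than this note shows. Statements on the series, on what has been measured and on what is new or still open speak of the compounds shown alone.

- compound 1 `Cc1cc(C)cc(NC(=O)NCCNS(=O)(=O)c2ccc(-c3ccccc3Oc3ccc([N+](=O)[O-])c([N+](=O)[O-])c3)s2)c1` gives 9100 nM
- compound 2 `O=C(NCCNS(=O)(=O)c1ccc(-c2ccccc2Oc2ccc([N+](=O)[O-])c([N+](=O)[O-])c2)s1)Nc1ccc([N+](=O)[O-])cc1` gives 340 nM
- compound 3 `COc1cccc(NC(=O)NCCNS(=O)(=O)c2ccc(-c3ccccc3Oc3ccc([N+](=O)[O-])c([N+](=O)[O-])c3)s2)c1` gives 6700 nM

These values come from a functional assay on HL-60 cells (Homo sapiens) for inhibition, read by CCK-8 assay, with a stated time of 48 h (a lower number here means a stronger inhibitor, a higher number a weaker inhibitor), and compound 1 stands at the high end of them. Its nearest neighbour shows a 1.4-fold lower number from compound 1 to compound 3 (0.13 log units; within the scatter) and its furthest shows a 27-fold lower number from compound 1 to compound 2 (1.43 log units; beyond the scatter). The next compound, compound 4 `Cc1cc(C)cc(NC(=O)NCCNS(=O)(=O)c2ccc(-c3ccccc3Oc3ccc(N)cc3)s2)c1`, differs from compound 1 elsewhere in the molecule: 4-aminophenyl in place of 3,4-dinitrophenyl on an oxygen on an aromatic ring, in words 4-aminophenyl in place of 3,4-dinitrophenyl on an oxygen on an aromatic ring. Within the data shown here, no measured step touches that place. All three steps change the group on an amide-type nitrogen, so they bear on compound 4 only indirectly. They show that one group can move the numbers a long way, as in a 20-fold higher number from compound 2 to compound 3 (1.29 log units; beyond the scatter), although a change can also leave them within the scatter. The lowest number belongs to compound 2 at 340 nM with its added 4-nitrophenyl group, while compound 4 gives up its 3,4-dinitrophenyl group. That is thin support, resting on a single compound, but it points to a moderate move towards a higher number in this assay rather than a lower one. The expected step is a 2.2-fold higher number from compound 1 to compound 4 (0.34 log units; beyond the scatter) and it remains an estimate with wide uncertainty. Compound 4 is expected at 20000 nM, with an estimated range from 6000 nM to 60000 nM and no firmer claim possible.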

Compound 4, half-maximal inhibitory concentration: > 50000 nM
Compound 4: no number, only a limit; the forecaster's own chance of this, stated with the estimate: 30%; middle value at least 2.5-fold (0.39 log units) away from the limit.
By their numbers in this assay, from the lowest: compound 2; then compounds 3 and 1 (each within the scatter of the next). At a limit, above all of these: compound 4.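

Among these compounds, the step of an at least 5.4-fold higher number from compound 1 to compound 4 (0.73 log units; beyond the scatter) is the first one measured at this place, and it shows that the group on an oxygen on an aromatic ring can move the number beyond the scatter, as the group on the amide-type nitrogen already did. The result for compound 4 in this assay is a limit and not a number: the limit of > 50000 nM in this assay, at which 1 of the 4 values shown sits. From the compounds shown here alone, for this pair, exchanging 3,4-dinitrophenyl for 4-aminophenyl moves the number towards a weaker inhibitor, but the true size of the step stays unknown and the direction rests on this one pair.

The exchange removes both nitro groups and brings in an amine at once, and a single pair cannot tell which of these changes carries the step. The compounds shown also leave open how an unsubstituted phenyl or a methoxyphenyl would behave on this oxygen, and whether the same exchange would have a like effect in compound 2, with its 4-nitrophenyl group on the amide-type nitrogen.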